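A Chloro Added to the Benzoyl Ring of Compound 2

The source may hold more compounds than are shown below. What is called first, only, known or untested is meant among the compounds shown, and "the series" means these compounds.

Measured so far:
compound 1 `O=C(Nc1ccc(Cl)c(-c2ccccn2)c1)c1cccnc1` — 600 nM
compound 2 `O=C(Nc1ccc(Cl)c(-c2ccccn2)c1)c1ccccc1` — 800 nM

Both compounds share a core and were tested in an assay on C3H 10T1/2 cells for inhibition of Sonic hedgehog protein (Mus musculus), read by a luciferase reporter; a lower number here means a stronger inhibitor, a higher number a weaker inhibitor. Compound 1 gives 600 nM, and compound 2 gives 800 nM. Among the measured compounds shown here, the one measured step, a 1.3-fold higher number from compound 1 to compound 2 (0.12 log units; within the scatter), is within the scatter, so compound 2 sits with the higher of the two numbers without standing apart from compound 1.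

Compound 3 `O=C(Nc1ccc(Cl)c(-c2ccccn2)c1)c1ccccc1Cl` differs from compound 2 by a single change: chloro in place of hydrogen on an aromatic carbon. For the measured compounds named here, no measured step concerns a substituent on this ring; the only step known swaps the whole ring on the carbonyl carbon and stays within the scatter. There is therefore nothing to point to a step in either direction, and for this assay no step beyond the scatter is expected. For compound 3 the estimated value is 700 nM, expected within 250 nM to 2500 nM, which corresponds to an expected 1.1-fold lower number from compound 2 to compound 3 (0.06 log units; within the scatter).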

Compound 3, half-maximal inhibitory concentration: 110 nM
The estimate for compound 3 lay 6.4-fold (0.80 log units) above the measured number; measured number outside the range, below it.
By their numbers in this assay, from the lowest: compound 3; then compounds 1 and 2 (each within the scatter of the next).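

In this assay, the ring on the carbonyl carbon had so far shown no effect beyond the scatter, but this position on the phenyl ring, ortho to a large group, responds clearly: adding one chloro gives a 7.3-fold lower number from compound 2 to compound 3 (0.86 log units; beyond the scatter), the first change here to move the number beyond the scatter. Going from the pyridin-3-yl ring to 2-chlorophenyl gives a 5.5-fold lower number from compound 1 to compound 3 (0.74 log units; beyond the scatter), so compound 3 stands apart as the strongest inhibitor of the three. Nothing available here explains why this single atom matters so much.

On these data alone, it remains open whether chloro is special or whether another small group at this place, such as fluoro, methyl or methoxy, would do the same. Also open, as far as these compounds go, is whether an amine or a carboxylic acid would be tolerated there.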